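Ring stereocentre inversion in a three-compound antagonist set

The source may report more compounds than this note shows. Statements on the series, on what has been measured and on what is new or still open speak of the compounds shown alone.

Measured so far:
compound 1, `O[C@H](c1ccccn1)[C@@]1(c2ccc(Cl)c(Cl)c2)CCO1`, 380 nM
compound 2, `C[C@]1(O)C[C@](c2cc(C(F)(F)F)ccn2)([C@H](O)c2ccccn2)C1`, 560 nM
compound 3, `O[C@H](c1ccccn1)[C@]1(c2cc(C(F)(F)F)ccn2)C[C@@H](O)C1`, 320 nM

All three values come from an assay on HEK293 cells for antagonist activity at transient receptor potential cation channel subfamily V member 3 (Homo sapiens), read by FLIPR and calcium flux; on this read-out higher numbers stand for weaker inhibition and lower numbers for stronger inhibition. Compound 1 holds the second highest of the three numbers. Its nearest neighbour is compound 3, whose value lies within the usual scatter of that of compound 1; the furthest is compound 2, and that gap also stays within the scatter. On these numbers the three compounds cannot be told apart.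

Compound 4, `O[C@H](c1ccccn1)[C@]1(c2ccc(Cl)c(Cl)c2)CCO1`, is not yet measured in this assay. Its relation to compound 1: the two compounds have the same atoms and bonds and differ only in configuration as drawn: 1 of 2 stereo elements differ; a stereocentre at a saturated ring carbon is drawn S in compound 1 and R in compound 4. Among the compounds with values here, no pair of measured compounds shares this kind of change, so the set gives no step to lean on. A change at a stereocentre can leave the number unchanged or move it well beyond the scatter in either direction; with nothing to anchor it, the expectation is a modest loss, and the step from a 2.4-fold higher number from compound 1 to compound 4 (0.37 log units; beyond the scatter) is expected to go upward. The value of compound 4 in this assay is estimated at 900 nM, with a range from 200 nM to 4000 nM.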

Compound 4, antagonist equilibrium constant: 150 nM
The estimate for compound 4 lay 6.0-fold (0.78 log units) above the measured number; the measured number lies below the stated range.
By their numbers in this assay, from the lowest: compound 4; then compounds 3, 1 and 2 (each within the scatter of the next).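

In this assay, within the data shown here, the stereocentre at the saturated ring carbon is the first change to give a step beyond the scatter: a 2.5-fold lower number from compound 1 to compound 4 (0.40 log units; beyond the scatter). The earlier compounds shown here, all within the scatter of one another, offered no such reading, and this step can be assigned to that stereocentre alone because nothing else separates the pair: the fact that compounds 1 and 4 differ only in the configuration as drawn. Configuration at this carbon therefore counts on the core of compound 1, with the R form as drawn giving the stronger inhibition, though the step is modest.

Whether the same inversion moves the number in the same direction on the cores of compound 2 and compound 3 stays open, since the compounds shown hold only this one pair. Also open, as far as these compounds go, is whether the R form keeps its advantage with an amine or a carboxylic acid on the core of compound 4.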